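Quinazoline series: phenyl for methyl on the ring amine

The compounds below may be only part of what the source reports. "The series", "measured", "known", "first", "only" and "open" are said of these compounds alone.

Three compounds of one shared core carry measurements in an assay on thoracic aorta (strain Wistar) for antagonist activity at Adrenergic receptor alpha-1 (Rattus norvegicus), with a stated time of 30 min; a higher number here means weaker binding, a lower number tighter binding. Compound 1, `COc1cc2nc(Nc3ccc(C)cc3)nc(N)c2cc1OC`, gives 2.95 nM. Compound 2, `COc1cc2nc(CNc3ccc([N+](=O)[O-])cc3)nc(N)c2cc1OC`, gives 0.417 nM. Compound 3, `COc1cc2nc(N3CCN(C)CC3)nc(N)c2cc1OC`, gives 0.589 nM. Within these three numbers compound 3 stands second highest: its nearest neighbour is compound 2, whose number lies lower by an amount within the scatter, so no order between compound 2 and compound 3 can be claimed; its furthest neighbour is compound 1, whose number lies higher by an amount beyond the scatter, so compound 3 binds tighter than compound 1.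

Compound 4, `COc1cc2nc(N3CCN(c4ccccc4)CC3)nc(N)c2cc1OC`, has not been measured in this assay. It differs from compound 3 in one place: phenyl in place of methyl on an amine nitrogen in a ring. Within the data shown here, no step between two measured compounds covers this kind of change, so nothing measured fixes its size. What the numbers do show is that an aromatic ring hung on the two-position substituent, as in compound 1 and compound 2, sits in the same low range as the methyl-bearing ring amine of compound 3. On that basis the step from compound 3 to compound 4 is expected to be small, a 1.5-fold lower number from compound 3 to compound 4 (0.17 log units; within the scatter), leaning toward a lower number but not clearly beyond the scatter. For compound 4 the estimate in this assay is 0.4 nM, with a range from 0.1 nM to 1.5 nM.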

Compound 4, dissociation constant: 1.82 nM
Compound 4: middle estimate off by 4.6-fold (0.66 log units), on the low side; the whole stated range lies below it.
By their numbers in this assay, from the lowest: compounds 2 and 3 (each within the scatter of the next); then compounds 4 and 1 (each within the scatter of the next).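

In this assay, among these compounds, the change of methyl to phenyl on the amine nitrogen in the ring gives a 3.1-fold higher number from compound 3 to compound 4 (0.49 log units; beyond the scatter), a modest weakening of binding that lies beyond the scatter and is the only single-place step available. This position therefore does not accept phenyl without a measurable change, even though neither group brings a hydrogen-bond donor, a hydrogen-bond acceptor or a net charge, and the entering group differs by its six carbon atoms and its aromatic ring. Nothing measured bears on why the number moves, so the step stands as an observation only.

On these data alone, whether the weakening follows the aromatic ring or simply the added carbon atoms stays open, and cyclohexyl or ethyl on the same nitrogen would help to separate the two. Also open, as far as these compounds go, is how benzyl, with its ring held one carbon further out, or acetyl, which places a carbonyl on that nitrogen, would compare with methyl and phenyl at this position.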